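Pyridin-2-ylmethoxy analogue of a sulfonamide cytotoxic series

A few compounds are considered here, and "the series" means these few. Any claim that something is new, unique, unknown or untested is made for them only; others in the source may bear on it.

Measured compounds:
compound 1 `CC(=O)SCC(=O)c1ccc(NS(=O)(=O)c2ccc(OC3CCCN(C)C3)cc2)nc1`, 3700 nM
compound 2 `COc1ccc(S(=O)(=O)Nc2ccc(C(=O)CSC(C)=O)cn2)cc1`, 540 nM

Two compounds have numbers in a functional assay on HCT-116 cells (Homo sapiens) for cytotoxicity; on this read-out lower numbers stand for an effect already at smaller amounts and higher numbers for an effect only at larger amounts of compound. Compound 2 stands lowest of the two; its nearest neighbour is compound 1, and the step of a 6.9-fold lower number from compound 1 to compound 2 (0.84 log units; beyond the scatter) lies beyond the scatter. Compound 3 `CC(=O)SCC(=O)c1ccc(NS(=O)(=O)c2ccc(OCc3ccccn3)cc2)nc1` differs from compound 2 by pyridin-2-yl in place of hydrogen on a saturated chain carbon bound to an oxygen on an aromatic ring. Going by the values given here, the only measured step that bears on this change is a 6.9-fold lower number from compound 1 to compound 2 (0.84 log units; beyond the scatter), which also replaced the group on an oxygen on an aromatic ring; there a methyl on that oxygen gave the lower number. Nothing measured speaks for (pyridin-2-yl)methoxy itself, so the size of the step is uncertain. A moderate rise in the number is expected for compound 3, a 2.8-fold higher number from compound 2 to compound 3 (0.44 log units; beyond the scatter). Compound 3 is estimated at 1500 nM in this assay, with a range from 500 nM to 5000 nM.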

Compound 3, half-maximal effective concentration: 420 nM
For compound 3 the middle estimate is 3.6-fold (0.55 log units) above the measured one; the whole stated range lies above it.
By their numbers in this assay, from the lowest: compounds 3 and 2 (each within the scatter of the next); then compound 1.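

In this assay, pyridin-2-yl on the saturated chain carbon bound to the oxygen on the aromatic ring makes no difference that can be told from scatter, with a 1.3-fold lower number from compound 2 to compound 3 (0.11 log units; within the scatter), so this position takes a group of 6 heavy atoms without a clear change in the read-out. The exchange of 1-methylpiperidin-3-yl for (pyridin-2-yl)methyl on that oxygen gives an 8.8-fold lower number from compound 1 to compound 3 (0.94 log units; beyond the scatter), which shows that a ring in this group does not by itself go with the higher number of compound 1. Nothing measured on these compounds explains either step.

From the compounds shown here alone, whether the higher number of compound 1 belongs to its ring nitrogen remains open, and a 2-(dimethylamino)ethyl group on the same oxygen would bear on that. Going by these compounds, it is also open how far this position tolerates other groups, such as a carboxylic acid at the end of a longer chain.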